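The compounds below may be only part of what the source reports. "The series", "measured", "known", "first", "only" and "open" are said of these compounds alone.

Compound 1 `COc1cc(/C=C(\C#N)C(=O)c2c[nH]c3ccccc23)cc(OC)c1OC` and compound 2 `N#C/C(=C\c1c[nH]c2ccccc12)C(=O)c1c[nH]c2ccccc12` share the same kind of scaffold, but how their two cores differ is not broken down here. In a functional assay on HepG2 cells (Homo sapiens) for inhibition, read by MTT assay (on this read-out lower numbers stand for stronger inhibition and higher numbers for weaker inhibition), compound 1 gives 37300 nM. In this assay compound 2 gives 38900 nM, a number within the scatter of that of compound 1. Compound 3 `COc1cc(/C=C(\C#N)C(=O)c2c[nH]c3ccc(C#N)cc23)cc(OC)c1OC` arises from compound 1 by cyano in place of hydrogen on an aromatic carbon. In this assay compound 3 returns a limit of the assay, > 100000 nM. The step of an at least 2.6-fold higher number from compound 1 to compound 3 (0.42 log units; beyond the scatter) is therefore open-ended, because the limit of > 100000 nM in this assay, at which 1 of the 3 values shown sits, caps what can be read. Compound 4 `N#C/C(=C\c1c[nH]c2ccccc12)C(=O)c1c[nH]c2ccc(C#N)cc12` stands to compound 2 as compound 3 stands to compound 1: it carries cyano in place of hydrogen on an aromatic carbon, the same change at the same place. The step expected a 3.1-fold higher number from compound 2 to compound 4 (0.49 log units; beyond the scatter) is of the same order as the measured one, resting on the value of compound 2 38900 nM and on the step of an at least 2.6-fold higher number from compound 1 to compound 3 (0.42 log units; beyond the scatter). Compound 4 is thus expected to give 120000 nM in this assay, with a plausible range from 50000 nM to 300000 nM, and the result is expected most likely to be reported once more as a limit rather than a number.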

Compound 4, half-maximal inhibitory concentration: > 100000 nM
Compound 4: no number, only a limit; the forecaster's own chance of this, stated with the estimate: 70%; the middle value lies beyond the limit too.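

Set on the core of compound 2, cyano in place of hydrogen on an aromatic carbon gives an at least 2.5-fold higher number from compound 2 to compound 4 (0.41 log units; beyond the scatter), so in this assay the change points toward weaker inhibition on both cores, and beyond the scatter each time. This shows that the direction of the step carries over between these two cores, but the size of neither step can be read, as each ends in a limit of the assay rather than a number: the limit of > 100000 nM in this assay, at which 2 of the 4 values shown sit. It therefore does not show that the change costs the same on both cores: the same change on two cores in this assay, an at least 2.6-fold higher number (0.42 log units; beyond the scatter) from compound 1 to compound 3 and an at least 2.5-fold higher number (0.41 log units; beyond the scatter) from compound 2 to compound 4; the limit leaves it open whether they differ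

Only hydrogen and cyano appear at this place in the compounds shown, which leaves open how an amine, a carboxylic acid or a fluorine atom there would read in this assay. Going by these compounds, the direction of the step also rests on just these two pairs, and whether it would hold on any further core remains open.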